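Series notes: replacing the acid-bearing group of compound 1

This account rests on a few compounds, and the source may have more. Where it says the series, first, only, none or still open, it means among the compounds named here.

Measured so far:
compound 1 `O=C(O)c1ccc2nc(CN3CCC[C@H](O[C@H](CO)c4cc(Cl)cc(Cl)c4)[C@@H]3c3ccccc3)[nH]c2c1` — 380 nM
compound 2 `Cc1cc(C(=O)O)ccc1CN1CCC[C@H](O[C@H](CO)c2cc(Cl)cc(Cl)c2)[C@@H]1c1ccc(F)cc1` — 18000 nM
compound 3 `Cc1cc(C(=O)O)ccc1CN1C(C)CC[C@H](O[C@H](CO)c2cc(Cl)cc(Cl)c2)[C@@H]1c1ccccc1` — 36000 nM

All three numbers come from an assay on isolated protein for activation of cGMP-dependent protein kinase 1 (Homo sapiens), read by ADP-Glo, with stated times of 30 min and 2 h, in the presence of a further agent that is not named here; on this read-out higher numbers stand for an effect only at larger amounts of compound and lower numbers for an effect already at smaller amounts. Compound 1 stands lowest of the three. The nearest of the others is compound 2, whose number lies well beyond the scatter above that of compound 1; compound 3 lies further still, also beyond the scatter. Going by the values given here, compounds 2 and 3 differ from compound 1 in more than one place, so no single step between measured compounds can be read from them.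

Compound 4 `Cc1nc(C(=O)O)ccc1CN1CCC[C@H](O[C@H](CO)c2cc(Cl)cc(Cl)c2)[C@@H]1c1ccccc1` is not yet measured. It differs from compound 1 in one place: a group of 10 heavy atoms (7 carbon, 1 nitrogen, 2 oxygen; one six-membered aromatic ring with 1 hetero atom) in place of a group of 12 heavy atoms (8 carbon, 2 nitrogen, 2 oxygen; one five-membered aromatic ring with 2 hetero atoms, one six-membered aromatic ring of carbon only), on a saturated chain carbon bound to an amine nitrogen in a ring

Among the compounds with values here, the only measured compounds that carry a six-membered aromatic acid-bearing group in place of the fused pair of rings, compounds 2 and 3, give much higher numbers than compound 1 in this assay, though their other differences leave the attribution open. On that basis a step upward, beyond the scatter, is expected from compound 1 to compound 4, namely a 7.9-fold higher number from compound 1 to compound 4 (0.90 log units; beyond the scatter). Compound 4 is therefore estimated at 3000 nM in this assay, with a range from 800 nM to 15000 nM.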

Compound 4, half-maximal effective concentration: 370 nM
The estimate for compound 4 lay 8.1-fold (0.91 log units) above the measured number; the measured number lies below the stated range.
By their numbers in this assay, from the lowest: compounds 4 and 1 (each within the scatter of the next); then compounds 2 and 3 (each within the scatter of the next).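

At the position on a saturated chain carbon bound to an amine nitrogen in a ring, this assay gives a 1.0-fold lower number from compound 1 to compound 4 (0.01 log units; within the scatter) when the group with one six-membered aromatic ring with 1 hetero atom replaces the group with one five-membered aromatic ring with 2 hetero atoms and one six-membered aromatic ring of carbon only. On the shared core, then, the fused pair of rings is not required for a number in this range, and a single six-membered aromatic ring carrying the carboxylic acid serves in its place, with fewer heavy atoms and 1 hydrogen-bond donor instead of 2. No measurement at hand gives a reason for this result.

Steps from compound 4 to compounds 2 and 3 cannot be read, as these compounds differ from it in more than one place, so the source of their higher numbers remains unresolved. Also open, going by these compounds, is whether the new group's ring nitrogen and methyl each matter on their own, and whether a tetrazole or a primary amide could stand in for the carboxylic acid at this position.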